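Bromine Removal Repeated on a Second Core

The source may hold more compounds than are shown below. What is called first, only, known or untested is meant among the compounds shown, and "the series" means these compounds.

In a functional assay on BGC-823 cells (Homo sapiens) for antiproliferative activity, read by MTT assay, with a stated time of 48 h (on this read-out lower numbers stand for stronger inhibition and higher numbers for weaker inhibition), compound 1 `Brc1ccc(CSc2nnc(-c3cnccn3)o2)cc1` gives 25700 nM. Compound 2 `c1ccc(CSc2nnc(-c3cnccn3)o2)cc1` carries the change that is the subject here, (hydrogen in place of bromo on an aromatic carbon), and in this assay compound 2 gives 25000 nM. The step of a 1.0-fold lower number from compound 1 to compound 2 (0.01 log units; within the scatter) is therefore small. Compound 3 `Brc1ccc(CSc2nnc(-c3cnccn3)s2)cc1` is built on a second core, and the difference between the core of compound 1 and the core of compound 3 is not broken down here. In this assay compound 3 gives 25200 nM, and its value and those of compound 1 and compound 2 all lie within the scatter of one another, so no order among the three can be read.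

Compound 4 `c1ccc(CSc2nnc(-c3cnccn3)s2)cc1` has not yet been measured. It differs from compound 3 by hydrogen in place of bromo on an aromatic carbon, the same change as that made between compound 1 and compound 2, at a place described in the same words. Because the step of a 1.0-fold lower number from compound 1 to compound 2 (0.01 log units; within the scatter) stayed within the scatter, the same change on the core of compound 3 is expected to behave alike. The expected step for compound 4 is a 1.0-fold lower number from compound 3 to compound 4 (0.00 log units; within the scatter). Compound 4 is estimated to give 25000 nM in this assay, with a range expected between 12000 nM and 52000 nM. This expectation rests on one measured pair, compound 1 and compound 2, and on the closeness of compound 3 to both.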

Compound 4, half-maximal inhibitory concentration: 21200 nM
For compound 4 the middle estimate is 1.2-fold (0.07 log units) above the measured one, within the range that was stated.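

In this assay, hydrogen in place of bromo on the core of compound 3 gives a 1.2-fold lower number from compound 3 to compound 4 (0.08 log units; within the scatter), and the two cores do not differ in how they take this change: the same change on two cores in this assay, a 1.0-fold lower number (0.01 log units; within the scatter) from compound 1 to compound 2 and a 1.2-fold lower number (0.08 log units; within the scatter) from compound 3 to compound 4, 1.2-fold (0.06 log units) apart, within the scatter of two such steps Both steps lie within the scatter, so what carries over from one core to the other is only the absence of a readable effect of this replacement. That does not show that the two cores would respond alike to a change that moves the value beyond the scatter, since neither pair contains such a step, and two pairs sharing one replacement cannot establish a rule for the series as a whole.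

The compounds shown leave open whether any group other than bromo or hydrogen, such as an amine, a carboxylic acid or a methoxy group, would shift the value at this aromatic carbon, on either core, by more than the scatter. They also leave open whether a longer chain in the part that carries this six-membered aromatic ring of carbon only would change the picture, and whether the two cores would then still behave alike.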